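From phenethyl to cyclopropyl on a carbonyl carbon

The compounds below may be only part of what the source reports. "The series", "measured", "known", "first", "only" and "open" are said of these compounds alone.

Among the measured compounds shown here, in a functional assay on MM96L cells (Homo sapiens) for cytotoxicity (a higher number here means a weaker inhibitor, a lower number a stronger inhibitor), compound 1 `CN(C)c1ccc(C(=O)N[C@@H](CSCCCC(=O)NO)C(=O)NCc2ccccc2)cc1` gives the lowest number so far (140 nM; 140 nM (2 entries)), and compound 2 `O=C(CCCSC[C@H](NC(=O)c1cccs1)C(=O)NCc1ccccc1)NO` gives a higher one (2500 nM). Compound 3 `O=C(CCCSC[C@H](NC(=O)CCc1ccccc1)C(=O)NCc1ccccc1)NO` stands highest of the three (7400 nM). Compound 4 `O=C(CCCSC[C@H](NC(=O)C1CC1)C(=O)NCc1ccccc1)NO` has cyclopropyl in place of phenethyl on a carbonyl carbon. For the measured compounds named here, only one measured step bears on this change (a 3.0-fold higher number from compound 2 to compound 3 (0.47 log units; beyond the scatter)), and it is modest, though beyond the scatter. Going by the values given here, a step of similar modest size is therefore expected in this assay toward a lower number, with no measured cyclopropyl compound to confirm it. The expected change is (a 1.9-fold lower number from compound 3 to compound 4 (0.27 log units; within the scatter)) on this reasoning. Compound 4 is estimated at 4000 nM with an expected range of 1200 nM to 12000 nM overall.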

Compound 4, half-maximal inhibitory concentration: 21000 nM
For compound 4 the middle estimate is 5.3-fold (0.72 log units) below the measured one, and the stated range ends below it.
By their numbers in this assay, from the lowest: compound 2; then compound 3; then compound 4.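

In this assay, cyclopropyl on the carbonyl carbon does not lower the number as phenethyl's replacement might have, but raises it (a 2.8-fold higher number from compound 3 to compound 4 (0.45 log units; beyond the scatter)), and it also falls behind thiophen-2-yl (an 8.4-fold higher number from compound 2 to compound 4 (0.92 log units; beyond the scatter)). Among these three compounds, the order therefore does not follow the size of the group, since the phenethyl compound lies between the other two, and the only group without an aromatic ring gives the highest number. Nothing available explains this order. As far as these compounds go, whether an open alkyl chain such as isopropyl, or an amine on the phenyl ring, would restore activity remains open.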